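Swapping formyl for methoxy on a pyranone-linked phenyl ring

The source may hold more compounds than are shown below. What is called first, only, known or untested is meant among the compounds shown, and "the series" means these compounds.

Measured so far:
Compound 1 `Cc1cc(-c2ccc(Cl)cc2)cc(=O)o1`: > 50000 nM
Compound 2 `Cc1cc(-c2ccc(C=O)cc2)cc(=O)o1`: 19200 nM

Two compounds share one core and differ only in the group on the six-membered carbon ring. In a functional assay on A2780 cells (Homo sapiens) for inhibition (a higher number here means a weaker inhibitor, a lower number a stronger inhibitor), compound 1 reaches only a limit of the assay, > 50000 nM, and no number. In this assay, among the measured compounds shown here, compound 2 gives 19200 nM, the only plain number among the two values shown; the other value is the limit of > 50000 nM in this assay, at which 1 of the 2 values shown sits. For the measured compounds named here, the step of an at least 2.6-fold lower number from compound 1 to compound 2 (0.41 log units; beyond the scatter) is the single measured change, and it shows that the group at this position matters.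

Compound 3 `COc1ccc(-c2cc(C)oc(=O)c2)cc1` carries the change (methoxy in place of formyl on an aromatic carbon). Going by the values given here, no measured step involves a methoxy group, so the only guide is that the formyl group in compound 2 gave a stronger result than the chloro group in compound 1. A new group at the same position is therefore expected to move the number, most likely back toward weaker inhibition, as a step of about a 1.8-fold higher number from compound 2 to compound 3 (0.26 log units; within the scatter). Compound 3 is estimated at 35000 nM in this assay, within a range from 12000 nM to 100000 nM.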

Compound 3, half-maximal inhibitory concentration: > 50000 nM
Compound 3 ended at the assay's limit; the forecaster's own chance of this, stated with the estimate: 40%; at least 1.4-fold (0.15 log units) between middle value and limit.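

With an at least 2.6-fold higher number from compound 2 to compound 3 (0.41 log units; beyond the scatter), the result shows that what counts at this position is not just the size of the group. Methoxy and formyl have the same counts of heavy atoms and hydrogen-bond acceptors, yet only formyl gives a plain number in this assay, and its steps to both chloro and methoxy lie beyond the scatter. Among these three compounds, compound 2 is therefore the strongest inhibitor, and two quite different groups on this aromatic carbon, chloro and methoxy, both end at the same limit: the limit of > 50000 nM in this assay, at which 2 of the 3 values shown sit.

The step from compound 1 to compound 3 cannot be read, and these two limits give no order between chloro and methoxy. The compounds shown leave open whether the gain with formyl depends on its carbonyl, which a comparison with an acetyl group, a carboxylic acid or a hydroxymethyl group on the same aromatic carbon could begin to answer, and whether an amine there would bring the number down at all.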